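The source may hold more compounds than are shown below. What is called first, only, known or untested is meant among the compounds shown, and "the series" means these compounds.

Compound 1 `N#Cc1ccc(NC(=O)CN2C(=O)/C(=C/c3ccc(-c4ccc(Cl)cc4)o3)SC2=S)cc1`: in a functional assay on K562 cells (Homo sapiens) for cytotoxicity, read by MTT assay, with a stated time of 72 h (a lower number here means a stronger inhibitor, a higher number a weaker inhibitor), compound 1 gives 85000 nM.
Compound 2 `O=C(CN1C(=O)/C(=C/c2ccc(-c3ccc(Cl)cc3)o2)SC1=S)NCc1ccc(F)cc1`: in this assay compound 2 gives 150000 nM.

Both compounds share the same core and differ only in the group carried on the amide-type nitrogen. Compound 2 has the higher of the two numbers, and its nearest neighbour is compound 1, but the step of a 1.8-fold higher number from compound 1 to compound 2 (0.25 log units; within the scatter) lies within the scatter, so the two cannot be told apart on these data. Compound 3 `Cc1cccc(CNC(=O)CN2C(=O)/C(=C/c3ccc(-c4ccc(Cl)cc4)o3)SC2=S)c1` has not yet been measured. It differs from compound 2 by 3-methylphenyl in place of 4-fluorophenyl on a saturated chain carbon bound to an amide-type nitrogen. Within the data shown here, only one measured step exists to guide this, a 1.8-fold higher number from compound 1 to compound 2 (0.25 log units; within the scatter), and it exchanges a 4-cyanophenyl for a 4-fluorobenzyl, a larger edit than the one leading to compound 3, which keeps the benzyl-type link and changes only the ring on it. That single step stayed within the scatter, so for compound 3 no step beyond the scatter is expected in this assay, in either direction. The expected step is no change at the digits printed from compound 2 to compound 3 (within the scatter). Compound 3 is therefore estimated at 150000 nM, with a range from 50000 nM to 400000 nM.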

Compound 3, half-maximal inhibitory concentration: 48000 nM
Compound 3: the middle estimate sits 3.1-fold (0.49 log units) above what was measured; measured number below the stated range.
By their numbers in this assay, from the lowest: compounds 3, 1 and 2 (each within the scatter of the next, the first and the last beyond it).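

Among these compounds, exchanging 4-fluorophenyl for 3-methylphenyl on a saturated chain carbon bound to an amide-type nitrogen gives, in this assay, a 3.1-fold lower number from compound 2 to compound 3 (0.49 log units; beyond the scatter), the first step in this small set to lie beyond the scatter. The ring on this benzyl link can therefore move the number, even though both groups count the same heavy atoms and neither carries a hydrogen-bond donor or acceptor. The other new comparison, 3-methylbenzyl in place of 4-cyanophenyl on an amide-type nitrogen, gives a 1.8-fold lower number from compound 1 to compound 3 (0.25 log units; within the scatter) and stays within the scatter, so compound 1 cannot be told apart from compound 3 any more than from compound 2, and only compound 2 and compound 3 stand apart.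

Nothing available here accounts for the step from 4-fluorophenyl to 3-methylphenyl. That step changes the group and its ring position at once, so the compounds shown leave open whether the methyl group, its place or the loss of fluorine matters, a question that 3-fluorobenzyl and 4-methylbenzyl would separate, while an amine or a carboxylic acid on the same ring remains unexplored.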